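Cyclopropylmethyl to azetidinyl: tolerability in HeLa cells

A few compounds are considered here, and "the series" means these few. Any claim that something is new, unique, unknown or untested is made for them only; others in the source may bear on it.

Compound 1 `CS(=O)(=O)CCCn1c(Cn2c(=O)n(CC#N)c3ccncc32)cc2cc(Cl)ccc21` in an ADME assay on HeLa cells (Homo sapiens) for cytotoxicity, read by ATP content, with a stated time of 3 days (a higher number here means that more compound is tolerated, a lower number that less compound is tolerated), gives > 50000 nM.
Compound 2 `CS(=O)(=O)CCCn1c(Cn2c(=O)n(CC3CC3)c3ccncc32)cc2cc(Cl)ccc21` in this assay gives > 50000 nM.

The value of compound 1 is a limit of the assay, not a measured number. The value of compound 2 is likewise a limit. The step from compound 1 to compound 2 is therefore a step that the two limits leave unreadable from compound 1 to compound 2, because both values sit at the limit of > 50000 nM in this assay, at which 2 of the 2 values shown sit. Within the data shown here, compound 2 thus stands at a limit, and the one other value shown is a limit as well; nothing here separates the two compounds.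

Compound 3 `CS(=O)(=O)CCCn1c(Cn2c(=O)n(C3CNC3)c3ccncc32)cc2cc(Cl)ccc21` differs from compound 2 by azetidin-3-yl in place of cyclopropylmethyl on an aromatic nitrogen. Among the measured compounds shown here, no measured step bears directly on this change, and the single step available is unreadable, so it offers no direction and no size. With both measured compounds at a limit, the expectation for compound 3 rests only on that fact. Compound 3 is expected to give about 60000 nM in this assay, within a range of 25000 nM to 150000 nM. The step from compound 2 to compound 3 is accordingly estimated as a step that the limit leaves unreadable from compound 2 to compound 3, not beyond the scatter, and most likely reported again as a limit.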

Compound 3, half-maximal cytotoxic concentration: > 50000 nM
Compound 3: a limit, no number (the forecaster's own chance of this, stated with the estimate: 80%); the middle value is on the limit's open side.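

Compound 3, like compound 1 and compound 2, is reported in this assay only as a limit and not as a number, so no step among these compounds can be read, because all three sit at the same limit: the limit of > 50000 nM in this assay, at which 3 of the 3 values shown sit.

The compounds shown leave open whether cyanomethyl, cyclopropylmethyl and azetidin-3-yl differ at all in this assay.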